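Benzothiophene in Place of Chlorophenyl on a Shared Core

A few compounds are considered here, and "the series" means these few. Any claim that something is new, unique, unknown or untested is made for them only; others in the source may bear on it.

Of the compounds shown here, three built on one shared core have been tested in an ADME assay on GES1 cells (Homo sapiens) for inhibition, read by MTT assay, with a stated time of 72 h; on this read-out lower numbers stand for stronger inhibition and higher numbers for weaker inhibition. Compound 1 `Cc1cc(Nc2cc(-c3ccccc3)[nH]n2)n2nc(SCc3ccc(F)cc3)nc2n1` gives 35500 nM, compound 2 `Cc1cc(Nc2cc(-c3ccccc3)[nH]n2)n2nc(SCc3ccccc3Br)nc2n1` gives 41100 nM, and compound 3 `Cc1cc(Nc2cc(-c3ccccc3)[nH]n2)n2nc(SCc3ccc(Cl)cc3)nc2n1` gives 31800 nM. Compound 3 carries the lowest of the three numbers, yet every step that connects them is small: a 1.2-fold higher number from compound 1 to compound 2 (0.06 log units; within the scatter), a 1.1-fold lower number from compound 1 to compound 3 (0.05 log units; within the scatter) and a 1.3-fold lower number from compound 2 to compound 3 (0.11 log units; within the scatter), each within the scatter, so none of the three can be called more or less active than another.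

Compound 4 `Cc1cc(Nc2cc(-c3ccccc3)[nH]n2)n2nc(SCc3csc4ccccc34)nc2n1` has not yet been measured. It differs from compound 3 by 1-benzothiophen-3-yl in place of 4-chlorophenyl on a saturated chain carbon bound to a sulfur. The measured steps that bear on this are the two that exchange the group on the saturated chain carbon bound to a sulfur, a 1.2-fold higher number from compound 1 to compound 2 (0.06 log units; within the scatter) and a 1.3-fold lower number from compound 2 to compound 3 (0.11 log units; within the scatter), and both stayed within the scatter as the group went from 4-fluorophenyl to 2-bromophenyl and on to 4-chlorophenyl. Within the data shown here, no measured step brings in a 1-benzothiophen-3-yl or any group with two rings, so the new change reaches beyond what the steps cover. The expected step is a 1.1-fold higher number from compound 3 to compound 4 (0.04 log units; within the scatter), not beyond the scatter. Compound 4 is therefore estimated at 35000 nM, within a range from 15000 nM to 80000 nM.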

Compound 4, half-maximal inhibitory concentration: 29200 nM
Beside the measured number, compound 4's estimate is 1.2-fold (0.08 log units) above it; low and high end bracket the measured number.
By their numbers in this assay, from the lowest: compounds 4, 3, 1 and 2 (each within the scatter of the next).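

In this assay the place on a saturated chain carbon bound to a sulfur now holds a group with two rings, and 1-benzothiophen-3-yl stays within the scatter of all three earlier groups: a 1.1-fold lower number from compound 3 to compound 4 (0.04 log units; within the scatter) and a 1.4-fold lower number from compound 2 to compound 4 (0.15 log units; within the scatter) and a 1.2-fold lower number from compound 1 to compound 4 (0.08 log units; within the scatter) are the steps that show it. Among these compounds, the earlier compounds had tested only a single six-membered aromatic ring of carbon carrying a fluoro, chloro or bromo group, so these four compounds extend the range of groups that leave the number unresolved to a fused second ring with a ring sulfur and no halogen. No measurement shown here gives a reason for these four numbers lying so close together.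

The compounds shown leave open whether an amine, a carboxylic acid or a longer carbon chain at this place would give a step beyond the scatter. They also leave open whether a change elsewhere on the shared core, which stays the same in all four compounds, would separate the numbers.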